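This account rests on a few compounds, and the source may have more. Where it says the series, first, only, none or still open, it means among the compounds named here.

Working notes on the series. The series is followed in a functional assay on CHO-K1 cells for antagonist activity at transient receptor potential cation channel subfamily V member 1 (Homo sapiens), read by FLIPR; a higher number here means a weaker inhibitor, a lower number a stronger inhibitor. Compound 1, `CC(C(=O)NCc1ccc(C(F)(F)F)nc1NCC1CCN(C(=O)OC(C)(C)C)CC1)c1ccc(NS(C)(=O)=O)c(F)c1`, gives 19.3 nM in this assay. Compound 2, `CC(C(=O)NCc1ccc(C(F)(F)F)nc1NCc1ccccc1)c1ccc(NS(C)(=O)=O)c(F)c1`, gives 15.8 nM in this assay. Compound 3, `Cc1ccc(CC2CCN(c3nc(C(F)(F)F)ccc3CNC(=O)C(C)c3ccc(NS(C)(=O)=O)c(F)c3)CC2)cc1`, gives 0.2 nM in this assay. For the measured compounds named here, compound 3 therefore holds the lowest number of the three; its nearest neighbour is compound 2 and the gap to it lies beyond the scatter, and the gap to compound 1, the furthest, also lies beyond the scatter, so compound 3 is the most potent compound measured so far.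

The next compound, compound 4, `CC(C(=O)NCc1ccc(C(F)(F)F)nc1N1CCC(C(=O)c2ccc(F)cc2)CC1)c1ccc(NS(C)(=O)=O)c(F)c1`, is not yet measured in this assay. It keeps the six-membered non-aromatic ring with one nitrogen that compound 3 carries on the shared core, and changes the group on that ring: (4-fluorophenyl)carbonyl in place of 4-methylbenzyl on a saturated ring carbon. Going by the values given here, no step between two measured compounds tests this exchange, so there is no direct precedent for its size.

Because compound 3 gives 0.2 nM with the same saturated ring in place, compound 4 is expected to stay well below compounds 1 and 2; a modest loss is estimated, the step from compound 3 to compound 4 being a 5.0-fold higher number from compound 3 to compound 4 (0.70 log units; beyond the scatter), giving an estimated 1 nM for compound 4, with a range from 0.2 nM to 6 nM.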

Compound 4, inhibition constant: 3.9 nM
Compound 4: middle estimate off by 3.9-fold (0.59 log units), on the low side; the range from low to high includes it.
By their numbers in this assay, from the lowest: compound 3; then compound 4; then compounds 2 and 1 (each within the scatter of the next).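

In this assay, for the compounds shown here, the exchange of 4-methylbenzyl for (4-fluorophenyl)carbonyl on the saturated ring carbon gives a 20-fold higher number from compound 3 to compound 4 (1.29 log units; beyond the scatter) and is large, so the group at this position, three ring bonds from the ring nitrogen, clearly matters to the read-out, which no earlier step could show. The six-membered aromatic ring of carbon only is present on both sides of the exchange, whereas the carbonyl with its hydrogen-bond acceptor and the fluorine enter together as the methyl leaves, so the step cannot be assigned to any one of these differences. Nothing available on these compounds accounts for a step of this size.

A 4-fluorobenzyl group or a 4-methylbenzoyl group on the same ring carbon would separate the effect of the carbonyl from that of the fluorine, and the compounds shown include neither. Also open is how an unsubstituted benzyl group, a hydroxyl group or an amine would behave at this position, as the compounds shown carry only these two groups there.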